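The source may report more compounds than this note shows. Statements on the series, on what has been measured and on what is new or still open speak of the compounds shown alone.

Of the compounds shown here, three of a shared core have been measured in an assay on isolated protein with Bile acid receptor (Homo sapiens) as the target; on this read-out higher numbers stand for an effect only at larger amounts of compound and lower numbers for an effect already at smaller amounts. Compound 1 `COC(=O)/C=C/c1cccc(N(Cc2ccc(/C=C/c3scnc3C)cc2)C(=O)C2CCCCC2)c1` gives 227 nM. Compound 2 `COC(=O)/C=C/c1cccc(N(Cc2ccc(/C=C/c3scnc3C)cc2)C(=O)C(C)C)c1`, which carries an isopropyl in place of the cyclohexyl on the carbonyl carbon, gives 228 nM, and a 1.0-fold higher number from compound 1 to compound 2 (0.00 log units; within the scatter). Compound 3 `COC(=O)/C=C/c1cccc(N(Cc2ccc(-c3ccc(C)cc3)cc2)C(=O)NC(C)C)c1` gives 449 nM. Compound 1 thus stands together with the other two, its number being separated from neither of theirs beyond the scatter.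

Compound 4 `COC(=O)/C=C/c1cccc(N(Cc2ccc(-c3c(OC)cccc3OC)cc2)C(=O)C2CCCCC2)c1` is the next compound, and it differs from compound 1 in one place: 2,6-dimethoxyphenyl in place of 2-(4-methyl-1,3-thiazol-5-yl)ethenyl on an aromatic carbon. Among the measured compounds shown here, no measured step touches this position. For the measured compounds named here, the one measured step, from compound 1 to compound 2, concerns the acyl group on the carbonyl carbon and says nothing about an exchange at the aromatic carbon para to a large group. Compound 3 carries a different group at that position but also a different acyl group, so its value against that of compound 1 shows only a gap within the scatter and cannot be attributed to either change.

The expectation for compound 4 is therefore set close to compound 1 with a wide range, a 1.8-fold higher number from compound 1 to compound 4 (0.25 log units; within the scatter), and compound 4 is estimated at 400 nM, between 120 nM and 1500 nM.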

Compound 4, half-maximal effective concentration: 77 nM
Estimate against measurement, compound 4: 5.2-fold (0.72 log units) above, and the stated range ends above it.
By their numbers in this assay, from the lowest: compound 4; then compounds 1, 2 and 3 (each within the scatter of the next).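

In this assay the exchange on the aromatic carbon para to a large group gives the only listed step that lies beyond the scatter (a 2.9-fold lower number from compound 1 to compound 4 (0.47 log units; beyond the scatter)), whereas the step on the carbonyl carbon stays within it (a 1.0-fold higher number from compound 1 to compound 2 (0.00 log units; within the scatter)). The position therefore responds to a change of group, and the 2-(4-methyl-1,3-thiazol-5-yl)ethenyl group, with its five-membered aromatic ring and its double bond outside aromatic rings, is not needed for a number in this range, since 2,6-dimethoxyphenyl, a six-membered aromatic ring of carbon only, gives a lower one. Nothing at hand bears on the reason for this step.

Going by these compounds, whether both methoxy groups count stays open, and a plain phenyl or a phenyl with a single methoxy would be needed to tell, as would a ring carrying an amine or a carboxylic acid to show how far this position tolerates other groups. Also open, on these data alone, is whether the lower number would hold with isopropyl on the carbonyl carbon in place of cyclohexyl.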